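This account rests on a few compounds, and the source may have more. Where it says the series, first, only, none or still open, it means among the compounds named here.

In a functional assay on HCT-8 cells (Homo sapiens) for antiproliferative activity, read by MTT assay, with a stated time of 48 h (on this read-out higher numbers stand for weaker inhibition and lower numbers for stronger inhibition), two compounds have been measured:
- compound 1 `COc1ccc(C(=O)c2ccc(OC)c3c2C=CC(C)(C)O3)c(NC(=O)CN(C)C)c1` gives 5660 nM
- compound 2 `C=C(c1cc(OC)c(OC)c(OC)c1)c1ccc(OC)c(O)c1NC(=O)COC` gives 280 nM

Compound 2 holds the lower of the two numbers, and the gap to compound 1 lies beyond the scatter. Compound 3 `C=C(c1cc(OC)c(OC)c(OC)c1)c1ccc(OC)c(O)c1NC(=O)CN(C)C` differs from compound 2 in one place, with dimethylamino in place of methoxy on a saturated chain carbon bound to a carbonyl carbon. For the measured compounds named here, no measured pair isolates this change. Compound 1 also carries dimethylamino and gives 5660 nM, but its core differs, so that number cannot separate the group from the core. The expected step, a 1.4-fold higher number from compound 2 to compound 3 (0.15 log units; within the scatter), is none beyond the scatter in this assay, leaning if anything toward weaker inhibition. For compound 3 the estimated value is 400 nM, with 100 nM to 1600 nM as the expected range.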

Compound 3, half-maximal inhibitory concentration: 110 nM
Estimate against measurement, compound 3: 3.6-fold (0.56 log units) above, and the stated range covers the measured number.
By their numbers in this assay, from the lowest: compound 3; then compound 2; then compound 1.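

In this assay, placing dimethylamino in place of methoxy on a saturated chain carbon bound to a carbonyl carbon gives a 2.5-fold lower number from compound 2 to compound 3 (0.41 log units; beyond the scatter), a modest step toward stronger inhibition on the shared core. Compound 1 also carries dimethylamino, but its different core left the effect of the group unresolved, whereas this single change shows that dimethylamino at this position goes with the lower number, not a higher one. Nothing among the available data offers an explanation for the step.

The compounds shown leave open whether a primary amine, a carboxylic acid or a longer chain at this position would give a number like that of dimethylamino or methoxy. They also leave open whether the same exchange would shift the number in the same direction on the core of compound 1.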